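From Cyclopentyl to ((4-Bromophenyl)carbamoyl)amino: Cytotoxicity Outlook

The compounds below may be only part of what the source reports. "The series", "measured", "known", "first", "only" and "open" are said of these compounds alone.

Compound 1, `COc1cc(NC(C)CCCNC(=O)NC2CCCC2)c2ncccc2c1`, carries a cyclopentyl group on an amide-type nitrogen. In an ADME assay on L6 cells (Rattus norvegicus) for cytotoxicity, read by resazurin assay, with a stated time of 70 h (on this read-out higher numbers stand for weaker inhibition and lower numbers for stronger inhibition), compound 1 is recorded as "not determined" (no result reported); its cytotoxicity was not determined. Compound 2, `COc1cc(NC(C)CCCNC(=O)NC2CCCCC2)c2ncccc2c1`, likewise stands in this assay as "not determined" (no result reported). For the measured compounds named here, the one measured member of the set is compound 3, `COc1cc(NC(C)CCCNC(=O)NNC(=O)/C=C/c2ccc(C(F)(F)F)cc2)c2ncccc2c1`; in this assay compound 3 gives 28300 nM, a weak effect on these rat muscle cells. Compound 4, `COc1cc(NC(C)CCCNC(=O)NNC(=O)Nc2ccc(Br)cc2)c2ncccc2c1`, has not yet been tested. Its structure arises from compound 1 by the change (((4-bromophenyl)carbamoyl)amino in place of cyclopentyl on an amide-type nitrogen). Going by the values given here, no measured pair in this set differs in a single place, so no step size can be read from the numbers, and no direction can be stated for this change beyond the scatter. The expectation for compound 4 therefore rests on compound 3, whose result 28300 nM shows that a nitrogen-rich substituent on this shared core is only weakly cytotoxic. In this assay compound 4 is expected to give 30000 nM, within an estimated range from 8000 nM to 100000 nM.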

Compound 4, half-maximal inhibitory concentration: 38700 nM
Beside the measured number, compound 4's estimate is 1.3-fold (0.11 log units) below it, within the range that was stated.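

In this assay, for the compounds shown here, the step of a 1.4-fold higher number from compound 3 to compound 4 (0.14 log units; within the scatter) is the first comparison this set allows, with (4-bromophenyl)amino in place of 2-(4-(trifluoromethyl)phenyl)ethenyl on a carbonyl carbon. The two compounds therefore cannot be told apart on this read-out, so exchanging these two aromatic groups at this place leaves no change that the measurement can resolve. No supporting evidence bears on this result.

Compound 1 and compound 2 have no single number, so the step from cyclopentyl to ((4-bromophenyl)carbamoyl)amino cannot be read. As far as these compounds go, it also remains open how this assay would respond if a simple amine, a carboxylic acid or a longer carbon chain stood on that carbonyl carbon in place of these aromatic groups.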